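From Fluoro to Nitro on Compound 3

The source may report more compounds than this note shows. Statements on the series, on what has been measured and on what is new or still open speak of the compounds shown alone.

Compound 1 `O=Cc1cn(CCCOc2ccc(Cl)cc2)c2ccccc12`: 4890 nM
Compound 2 `CC(C)Cn1cc(C=O)c2ccccc21`: > 31600 nM (a limit of the assay)
Compound 3 `OCc1cn(Cc2cccc(F)c2)c2ccccc12`: 20 nM

The three compounds were tested in a functional assay on T29Kt1 cells (Homo sapiens) for cytotoxicity, read by sulforhodamine B assay, with a stated time of 3 days; on this read-out lower numbers stand for stronger inhibition and higher numbers for weaker inhibition. Compound 3 stands lowest of the actual numbers, at 20 nM. The nearest neighbour of compound 3 is compound 1 at 4890 nM, and that gap lies well beyond the scatter. Compound 2 reads > 31600 nM, which is a limit of the assay and not a number.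

The next compound to be read is compound 4 `O=[N+]([O-])c1cccc(Cn2cc(CO)c3ccccc32)c1`. It departs from compound 3 in one place, with nitro in place of fluoro on an aromatic carbon, meta to a large group (nitro in place of fluoro on an aromatic carbon). Within the data shown here, no measured pair in this small set shows a swap of this kind, so the expectation rests on the structural change alone. In this assay a moderate step toward a higher number is expected, which would mean weaker inhibition, though a result within the scatter would not be surprising. Compound 3 at 20 nM appears to leave more room upward than downward. The estimated change is a 5.0-fold higher number from compound 3 to compound 4 (0.70 log units; beyond the scatter). For compound 4 the expected value is 100 nM, with an estimated range of 15 nM to 2000 nM.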

Compound 4, half-maximal inhibitory concentration: 390 nM
For compound 4 the middle estimate is 3.9-fold (0.59 log units) below the measured one; measured number inside the range.
By their numbers in this assay, from the lowest: compound 3; then compound 4; then compound 1. At a limit, above all of these: compound 2.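

In this assay, among these compounds, putting nitro in place of fluoro on an aromatic carbon, meta to a large group, gives a 20-fold higher number from compound 3 to compound 4 (1.29 log units; beyond the scatter) and is the first change in this set that can be read in one place alone. It shows that this position is not indifferent to what it carries: when the 1 heavy atom of fluoro gives way to the 3 heavy atoms of nitro, with its 2 hydrogen-bond acceptors, the number moves well beyond the scatter, although compound 4 still gives a measured number and not a limit. Nothing in the data shown bears on the reason for this step.

With a single swap at this place, the compounds shown leave open whether the size of the step tracks the group that enters, and how an amine, a nitrile or a methoxy group would read there. Among the compounds shown here, they also leave open whether the same swap would give a step of like size on a compound with a longer chain, such as the one compound 1 carries.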